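Oleoyl ketones on a heteroaryl carrier: compound 4

The source may hold more compounds than are shown below. What is called first, only, known or untested is meant among the compounds shown, and "the series" means these compounds.

Compound 3 `CCCCCCCC/C=C\CCCCCCC(=O)c1nccn1C` carries a long unsaturated chain on a carbonyl joined to a 1-methyl-1H-imidazol-2-yl group. In an assay on isolated protein for inhibition of Fatty-acid amide hydrolase 1 (Homo sapiens) (a lower number here means a stronger inhibitor, a higher number a weaker inhibitor), compound 3 returns only a limit, > 100000 nM, and so stands at the weak edge of the series. Going by the values given here, compound 2 `CCCCCCCC/C=C\CCCCCCC(=O)c1nc2ccccc2o1`, bearing a 1,3-benzoxazol-2-yl group on the same carbonyl, gives 370 nM in this assay, and the step of an at least 270-fold higher number from compound 2 to compound 3 (2.43 log units; beyond the scatter) is the only readable one touching compound 3. Compound 1 `CCCCCCCC/C=C\CCCCCCC(=O)c1ccccn1`, with a pyridin-2-yl group, also returns only a limit, > 100000 nM. The step that the two limits leave unreadable from compound 1 to compound 3 therefore cannot be sized, as both values sit at the limit of > 100000 nM in this assay, at which 2 of the 3 values shown sit.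

Compound 4 `CCCCCCCC/C=C\CCCCCCC(=O)c1cccnn1` differs from compound 3 by pyridazin-3-yl in place of 1-methyl-1H-imidazol-2-yl on a carbonyl carbon. The pyridazin-3-yl group that enters is, like the pyridin-2-yl of compound 1, a six-membered aromatic ring, and compound 1 sits at the limit. Only compound 2 shows a strong number, and the ring it carries is not the one entering here. Compound 4 is therefore expected to remain at the weak edge, with a number no higher from compound 3 to compound 4 (the limit leaves the size open) being no readable step; the estimate for compound 4 in this assay is 100000 nM, within 10000 nM to 1000000 nM.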

Compound 4, inhibition constant: 130 nM
Compound 4: middle estimate off by 770-fold (2.89 log units), on the high side, and the stated range ends above it.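

In this assay, a six-membered aromatic ring on the carbonyl carbon does not by itself leave a compound at the weak edge: pyridazin-3-yl and pyridin-2-yl are both such rings, yet exchanging one for the other gives an at least 760-fold lower number from compound 1 to compound 4 (2.88 log units; beyond the scatter). Matching counts do not settle the outcome at this place either, since pyridazin-3-yl and 1-methyl-1H-imidazol-2-yl have the same heavy atoms, hydrogen-bond donors and acceptors, and the exchange still gives an at least 760-fold lower number from compound 3 to compound 4 (2.88 log units; beyond the scatter). The 1,3-benzoxazol-2-yl group is also not required for a strong number, as its replacement by pyridazin-3-yl gives a 2.8-fold lower number from compound 2 to compound 4 (0.45 log units; beyond the scatter).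

Going by these compounds, compound 1 and compound 3 each remain a limit and not a number, so the step between them cannot be read and how far they truly lie from the others stays unknown: the limit of > 100000 nM in this assay, at which 2 of the 4 values shown sit. Also open is whether a pyrimidin-2-yl or a 1,3-oxazol-2-yl group on the same carbonyl carbon, or a saturated chain in place of the long unsaturated one, would keep a number like that of compound 4.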